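This account rests on a few compounds, and the source may have more. Where it says the series, first, only, none or still open, it means among the compounds named here.

Measured so far in a functional assay on C6 cells (Rattus norvegicus) for cytotoxicity, read by MTT assay, with a stated time of 24 h; on this read-out higher numbers stand for weaker inhibition and lower numbers for stronger inhibition:
- compound 1 `Cc1ccc(-c2cs/c(=N/NC(=O)CSc3nnnn3-c3ccccc3)n2-c2ccccc2)cc1`: 14.7 ug/mL
- compound 3 `O=C(CSc1ncccn1)N/N=c1/scc(-c2ccc(Cl)cc2)n1-c1ccccc1`: 83.3 ug/mL
- compound 2 `O=C(CSc1nnnn1-c1ccccc1)N/N=c1/scc(-c2ccc(Cl)cc2)n1-c1ccccc1`: a limit only, > 200 ug/mL

Compound 2 and compound 1 differ by methyl in place of chloro on an aromatic carbon. The step of an at least 13-fold lower number from compound 2 to compound 1 (1.13 log units; beyond the scatter). The cores of compound 2 and compound 3 differ by pyrimidin-2-yl in place of 1-phenyl-1H-tetrazol-5-yl on a sulfur, and the step of an at least 2.4-fold lower number from compound 2 to compound 3 (0.38 log units; beyond the scatter). Both of these steps start from the limit of > 200 ug/mL in this assay, at which 1 of the 3 values shown sits, so only their lower bound is known, not their full size.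

Compound 4 `Cc1ccc(-c2cs/c(=N/NC(=O)CSc3ncccn3)n2-c2ccccc2)cc1` has not yet been measured in this assay. Among the compounds with values here, it differs from compound 3 by methyl in place of chloro on an aromatic carbon, which is the same change as the one from compound 2 to compound 1, at the same place. The step is expected to be a 6.9-fold lower number from compound 3 to compound 4 (0.84 log units; beyond the scatter); this expectation rests on compound 2 and compound 1, whose step was an at least 13-fold lower number from compound 2 to compound 1 (1.13 log units; beyond the scatter), with the reservation that the size of that step is only a bound. Compound 4 is therefore estimated at 12 ug/mL, with a range from 4 ug/mL to 45 ug/mL.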

Compound 4, half-maximal inhibitory concentration: 85 ug/mL
Beside the measured number, compound 4's estimate is 7.1-fold (0.85 log units) below it; measured number above the stated range.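

In this assay, methyl in place of chloro on the aromatic carbon gives a 1.0-fold higher number from compound 3 to compound 4 (0.01 log units; within the scatter) on the core bearing pyrimidin-2-yl, so the large step seen with 1-phenyl-1H-tetrazol-5-yl on the sulfur does not carry over to this core: the same change on two cores in this assay, an at least 13-fold lower number (1.13 log units; beyond the scatter) from compound 2 to compound 1 and a 1.0-fold higher number (0.01 log units; within the scatter) from compound 3 to compound 4, at least 13-fold (1.14 log units) apart, beyond the scatter of two such steps. The exchange on the sulfur does not carry over either, since pyrimidin-2-yl in place of 1-phenyl-1H-tetrazol-5-yl gives a 5.8-fold higher number from compound 1 to compound 4 (0.76 log units; beyond the scatter) on the methyl side, the opposite direction to the chloro side: the same change on two cores in this assay, an at least 2.4-fold lower number (0.38 log units; beyond the scatter) from compound 2 to compound 3 and a 5.8-fold higher number (0.76 log units; beyond the scatter) from compound 1 to compound 4, at least 13-fold (1.14 log units) apart, beyond the scatter of two such steps. This shows that in these four compounds neither change can be read across from one core to the other, but it does not show why, and compound 2 has only a limit, so the gaps are bounds and not full sizes: the limit of > 200 ug/mL in this assay, at which 1 of the 4 values shown sits.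

The compounds shown leave open how another group on that aromatic carbon, such as methoxy or fluoro, would behave on each core. They also leave open whether an amine or a carboxylic acid in place of the chloro or methyl would follow either pattern.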